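Enlarging the amide on compound 2: from dimethyl to diisopropyl

The source may hold more compounds than are shown below. What is called first, only, known or untested is meant among the compounds shown, and "the series" means these compounds.

compound 1 `CNC(=O)c1cccnc1NCCCN1CCN(c2ccccc2OC)CC1`: 3.16 nM
compound 2 `COc1ccccc1N1CCN(CCCNc2ccncc2C(=O)N(C)C)CC1`: 50.1 nM

In a functional assay on aorta for antagonist activity at Alpha-1D adrenergic receptor (Rattus norvegicus) (a higher number here means weaker binding, a lower number tighter binding), compound 1 gives 3.16 nM and compound 2 gives 50.1 nM. Compound 2 thus carries the higher of the two numbers, and its gap to compound 1 lies beyond the scatter. Compound 3 `COc1ccccc1N1CCN(CCCNc2ccncc2C(=O)N(C(C)C)C(C)C)CC1` differs from compound 2 in one place: diisopropylamino in place of dimethylamino on a carbonyl carbon. Among the compounds with values here, no measured pair isolates this change, so there is no measured step to lean on. The expected step is a 1.6-fold higher number from compound 2 to compound 3 (0.20 log units; within the scatter), small and within the usual scatter, with a slight drift toward a higher number. Compound 3 is therefore estimated at 80 nM, within a range from 20 nM to 320 nM.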

Compound 3, dissociation constant: 251 nM
The estimate for compound 3 lay 3.1-fold (0.50 log units) below the measured number; measured number inside the range.
By their numbers in this assay, from the lowest: compound 1; then compound 2; then compound 3.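

In this assay, within the data shown here, replacing dimethylamino with diisopropylamino on the carbonyl carbon gives a 5.0-fold higher number from compound 2 to compound 3 (0.70 log units; beyond the scatter), the first measured step at this place. The change adds only carbon atoms, with no hydrogen-bond donors or acceptors, yet binding clearly weakens, so this place does not accept the larger amide group without loss. Nothing measured here explains that loss. Still open, as far as these compounds go, is whether the number rises gradually with the size of the group, which one step cannot show. A diethylamino group on the same carbonyl carbon could test this.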